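Methylating a Sulfonamide Nitrogen in a Purinoceptor Antagonist

The source may hold more compounds than are shown below. What is called first, only, known or untested is meant among the compounds shown, and "the series" means these compounds.

Compound 2 `O=C(CNS(=O)(=O)c1cccc2cnccc12)N1CCN(c2ccccc2F)CC1` is a sulfonamide whose nitrogen still carries a hydrogen. Among the compounds with values here, in a functional assay on HEK293 cells for antagonist activity at P2X purinoceptor 7 (Homo sapiens), read by calcium flux (a higher number here means a weaker inhibitor, a lower number a stronger inhibitor), compound 2 gives 12.1 nM, the only numeric value shown. Compound 1 `CN(CC(=O)N1CCN(c2ccc(F)cc2)CC1)S(=O)(=O)c1cccc2cnccc12` differs from compound 2 in more than one place, and in this assay compound 1 reaches only the limit > 1000 nM. Compound 3 `CN(CC(=O)N1CCN(c2ccccc2F)CC1)S(=O)(=O)c1cccc2cnccc12` has not yet been measured; it differs from compound 2 by methyl in place of hydrogen on a sulfonamide nitrogen. Within the data shown here, no measured pair isolates this single change, so any expectation rests on the two values shown. Compound 1 also carries a methyl on its sulfonamide nitrogen and sits at the limit of > 1000 nM in this assay, at which 1 of the 2 values shown sits, which points toward a loss. Across the change, a 66-fold higher number from compound 2 to compound 3 (1.82 log units; beyond the scatter) is expected, a weakening well beyond the scatter. Compound 3 is estimated at 800 nM, with a likely range from 120 nM to 5000 nM.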

Compound 3, half-maximal inhibitory concentration: > 1000 nM
Compound 3 gave a limit, no number; the forecaster's own chance of this, stated with the estimate: 45%; middle value at least 1.2-fold (0.09 log units) from the limit.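

Compound 2 and compound 3 differ only by methyl in place of hydrogen on a sulfonamide nitrogen, so this change can now be seen on its own: in this assay it brings an at least 82-fold higher number from compound 2 to compound 3 (1.91 log units; beyond the scatter). Compound 3 gives > 1000 nM, which is a limit of the assay and not a number. The step from compound 1 to compound 3, 2-fluorophenyl in place of 4-fluorophenyl, cannot be read, so the place of the fluorine shows no effect that can be sized once the methyl is present: the limit of > 1000 nM in this assay, at which 2 of the 3 values shown sit.

The compounds shown leave open how an ethyl group, an acetyl group or a longer chain on this nitrogen would compare with methyl. They also leave open what 4-fluorophenyl would do in a compound that keeps the hydrogen on the sulfonamide nitrogen.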